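A few compounds are considered here, and "the series" means these few. Any claim that something is new, unique, unknown or untested is made for them only; others in the source may bear on it.

Within the data shown here, compound 2 `CC[C@H](C)[C@H](N)CN(C(=O)[C@@H]1C[C@H]1c1cncnc1)c1ccc(-c2ccccc2)cc1` is one of two compounds measured in a functional assay for agonist activity at G protein-coupled receptor 88 (Homo sapiens), read by HTRF and cAMP accumulation; a lower number here means that less compound is needed, a higher number that more compound is needed for the effect; compound 2 gives 19000 nM. Among the measured compounds shown here, its only neighbour is compound 1 `CC[C@H](C)[C@H](N)CN(C(=O)[C@@H]1C[C@H]1c1c(F)cccc1F)c1ccc(-c2ccccc2)cc1`, which in this assay gives 11000 nM, and the step of a 1.7-fold higher number from compound 1 to compound 2 (0.24 log units; within the scatter) sets compound 2 alongside rather than apart from compound 1. Compound 3 `CC[C@H](C)[C@H](N)CN(C(=O)[C@@H]1C[C@H]1c1nccs1)c1ccc(-c2ccccc2)cc1` differs from compound 2 by 1,3-thiazol-2-yl in place of pyrimidin-5-yl on a saturated ring carbon. For the measured compounds named here, the one measured step that bears on this change is the swap of the aromatic group on the same saturated ring carbon, a 1.7-fold higher number from compound 1 to compound 2 (0.24 log units; within the scatter), which did not move the number beyond the scatter. Nothing else in the measured set informs the thiazolyl group. Compound 3 is therefore expected to show a step of a 1.3-fold lower number from compound 2 to compound 3 (0.10 log units; within the scatter), with no movement beyond the scatter foreseen in either direction. The estimate for compound 3 in this assay is 15000 nM, within a range from 5000 nM to 45000 nM.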

Compound 3, half-maximal effective concentration: 210 nM
Beside the measured number, compound 3's estimate is 71-fold (1.85 log units) above it, and the stated range ends above it.
By their numbers in this assay, from the lowest: compound 3; then compounds 1 and 2 (each within the scatter of the next).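

The group on this saturated ring carbon of the three-membered ring matters in this assay: 1,3-thiazol-2-yl gives a 90-fold lower number from compound 2 to compound 3 (1.96 log units; beyond the scatter) when it replaces pyrimidin-5-yl and a 52-fold lower number from compound 1 to compound 3 (1.72 log units; beyond the scatter) when it replaces 2,6-difluorophenyl, whereas the earlier swap at this carbon stayed within the scatter. The entering and leaving groups of the first step have the same counts of hydrogen-bond donors and acceptors, so those counts do not separate compound 2 from compound 3. No measurement available here accounts for the size of these steps.

As far as these compounds go, it remains open whether the sulfur, the five-membered ring or the point of attachment carries the change. Equally open, from the compounds shown here alone, is what 1,3-oxazol-2-yl or 1,3-thiazol-5-yl would give on this carbon.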